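The source may report more compounds than this note shows. Statements on the series, on what has been measured and on what is new or still open speak of the compounds shown alone.

Compound 2 `CN(C)CCn1nc(Cc2ccc(Cl)cc2)c2ccccc2c1=O` was tested in an assay for binding affinity to Alpha-1B adrenergic receptor (Homo sapiens) (a higher number here means a weaker inhibitor, a lower number a stronger inhibitor), where compound 2 gives 200 nM. This is the lowest of the two numbers available, and the nearest is compound 1 `CN1CCC[C@@H]1Cn1nc(Cc2cccc(F)c2)c2ccccc2c1=O`, which in this assay gives 398 nM; the gap between these two lies within the usual scatter, so they cannot be told apart. Compound 3 `COc1cccc(Cc2nn(C[C@H]3CCCN3C)c(=O)c3ccccc23)c1` in this assay reaches only the limit of > 1990 nM. For compound 3 this is the limit of > 1990 nM in this assay, at which 1 of the 3 values shown sits. Among the compounds with values here, the one step computed between measured compounds runs an at least 5.0-fold higher number from compound 1 to compound 3 (0.69 log units; beyond the scatter), a change of a substituent on an aromatic carbon.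

Compound 4 `CN1CCC(Cn2nc(Cc3ccc(Cl)cc3)c3ccccc3c2=O)C1` differs from compound 2 on a saturated chain carbon bound to an aromatic nitrogen: 1-methylpyrrolidin-3-yl in place of (dimethylamino)methyl on a saturated chain carbon bound to an aromatic nitrogen. Within the data shown here, no measured step touches this part of the molecule. Compounds 1 and 2 differ both in the chain and in the aromatic substituent, and their values sit within the scatter of each other. In this assay the step from compound 2 to compound 4 is therefore expected to be a 1.3-fold higher number from compound 2 to compound 4 (0.10 log units; within the scatter), with no clear direction. Compound 4 is estimated at 250 nM, expected to fall between 80 nM and 800 nM.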

Compound 4, inhibition constant: 79.4 nM
Compound 4: the middle estimate sits 3.1-fold (0.50 log units) above what was measured; the measured number lies below the stated range.
By their numbers in this assay, from the lowest: compound 4; then compounds 2 and 1 (each within the scatter of the next). At a limit, above all of these: compound 3.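

In this assay, exchanging the open 2-(dimethylamino)ethyl chain for the ring-containing (1-methylpyrrolidin-3-yl)methyl gives a 2.5-fold lower number from compound 2 to compound 4 (0.40 log units; beyond the scatter), so the group on this saturated chain carbon bound to an aromatic nitrogen does affect the number. Within the data shown here, the only earlier step changed a substituent on an aromatic carbon, so this is the first direct reading at this place, and it shows that adding a five-membered non-aromatic ring here goes with a lower number, not a higher one. Nothing measured here explains why this change lowers the number.

Compounds 1 and 3 also carry a ring in this part, but each differs from compound 4 in more than one place, so those pairs cannot be read. As far as these compounds go, whether a six-membered piperidine ring, or a pyrrolidine without the methyl on its nitrogen, would do the same remains open.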